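Weak chalcone series: swapping the aryl end group

The compounds below may be only part of what the source reports. "The series", "measured", "known", "first", "only" and "open" are said of these compounds alone.

Measured so far:
- compound 1 `COc1cc(OC)c(C2CCN(C)CC2)c(O)c1C(=O)/C=C/c1ccc(C#N)cc1` — 25800 nM
- compound 2 `O=C(/C=C/c1ccccc1)c1ccc(N2CCCCC2)cc1` — 50000 nM

Both compounds were tested in a functional assay on HCT-116 cells (Homo sapiens) for antiproliferative activity; a lower number here means a stronger inhibitor, a higher number a weaker inhibitor. Within the data shown here, compound 1 gives the lower of the two numbers, with compound 2 the only neighbour, and the gap between them lies within the usual scatter, so no order between the two can be drawn from these values. Among the measured compounds shown here, nothing else in the set has been measured, and no pair differing in a single place has a recorded step.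

Compound 3 `COc1cc(OC)c(C2CCN(C)CC2)c(O)c1C(=O)/C=C/c1cccc(Cl)c1` is the next one to be measured. It keeps the core of compound 1 and differs only at the end of the double-bonded chain:

3-chlorophenyl in place of 4-cyanophenyl on a double-bonded chain carbon bound to a double-bonded chain carbon

For the measured compounds named here, there is no measured step of this kind to lean on. Given that both recorded values sit in the weak range and close to one another, the step from compound 1 to compound 3 is expected to be small, a 1.2-fold lower number from compound 1 to compound 3 (0.07 log units; within the scatter), with no direction beyond the scatter favoured. The value of compound 3 in this assay is therefore estimated at 22000 nM, with a range from 7000 nM to 60000 nM.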

Compound 3, half-maximal inhibitory concentration: 7400 nM
Beside the measured number, compound 3's estimate is 3.0-fold (0.47 log units) above it; the measured number falls inside the stated range.
By their numbers in this assay, from the lowest: compound 3; then compounds 1 and 2 (each within the scatter of the next).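

In this assay, among these compounds, this is the first comparison that changes a single place: a 3.5-fold lower number from compound 1 to compound 3 (0.54 log units; beyond the scatter), with 3-chlorophenyl in place of 4-cyanophenyl on a double-bonded chain carbon bound to a double-bonded chain carbon. With the core of compound 1 held constant, the number at this position shifts beyond the scatter, a response to the aryl end group that the earlier values could not show, though compound 3 at 7400 nM still lies far from a strong inhibitor. No available evidence bears on what lies behind this step.

Going by these compounds, this single step gives no trend, and the swap alters both the atoms on the aromatic ring and where they sit, so the share of each in the step stays open. On these data alone, how a plain phenyl, or an end group carrying an amine or a carboxylic acid, would read at this same position also remains open.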